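From hydroxy to methoxy on the benzyl group

This account rests on a few compounds, and the source may have more. Where it says the series, first, only, none or still open, it means among the compounds named here.

compound 1 `Cc1cc(-c2c(F)cc3c(=O)ccn(C4CC4)c3c2F)cc(C)n1` 15000 nM
compound 2 `Cc1cc(-c2c(F)cc3c(=O)c(Cc4cccc(O)c4)cn(C4CC4)c3c2F)cc(C)n1` 2200 nM

In a functional assay on P388 cells (Mus musculus) for cytotoxicity (a lower number here means a stronger inhibitor, a higher number a weaker inhibitor), compound 2 holds the lower of the two numbers (2200 nM). Among the compounds with values here, the only measured step (a 6.8-fold lower number from compound 1 to compound 2 (0.83 log units; beyond the scatter)) is modest but beyond the scatter, and it came with 3-hydroxybenzyl in place of hydrogen on an aromatic carbon.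

Compound 3 (`COc1cccc(Cc2cn(C3CC3)c3c(F)c(-c4cc(C)nc(C)c4)c(F)cc3c2=O)c1`) alters that group: methyl in place of hydrogen on an oxygen on an aromatic ring, with methyl in place of hydrogen on an oxygen on an aromatic ring, so 3-hydroxybenzyl becomes 3-methoxybenzyl. Within the data shown here, no measured step shows this exact change. The step to compound 2 (a 6.8-fold lower number from compound 1 to compound 2 (0.83 log units; beyond the scatter)) installed the whole group, so it bears only loosely on this much smaller edit and gives no direction. The expected result is no step beyond the scatter (a 1.1-fold higher number from compound 2 to compound 3 (0.06 log units; within the scatter)). In this assay the estimated value for compound 3 is 2500 nM, with an expected range from 800 nM to 7000 nM.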

Compound 3, half-maximal inhibitory concentration: 20000 nM
Compound 3: middle estimate off by 8.0-fold (0.90 log units), on the low side, and the stated range ends below it.
By their numbers in this assay, from the lowest: compound 2; then compounds 1 and 3 (each within the scatter of the next).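

In this assay the single added methyl, which turns 3-hydroxybenzyl into 3-methoxybenzyl, has a clear effect (a 9.1-fold higher number from compound 2 to compound 3 (0.96 log units; beyond the scatter)), so this position responds to a very small edit on the oxygen. With the whole 3-methoxybenzyl group added to the parent compound, the step stays within the scatter (a 1.3-fold higher number from compound 1 to compound 3 (0.12 log units; within the scatter)), so among these compounds a benzyl group alone does not bring the lower number, and only the hydroxy form does. Nothing available explains this difference.

On these data alone, it remains open whether the lower number depends on the hydroxy hydrogen itself or on something more specific to the hydroxy group. An amine or a carboxylic acid in place of the hydroxy, or an ethyl or longer chain on the oxygen, could help separate these possibilities.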